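A Methyl Added to the Anilino Ring of Compound 2

This account rests on a few compounds, and the source may have more. Where it says the series, first, only, none or still open, it means among the compounds named here.

compound 1 `COc1cccc(/C=C/C(=O)c2sc(Nc3ccccc3)nc2C)c1`: a limit, > 25000 nM, in a functional assay on Bel-7402 cells (Homo sapiens) for cytotoxicity, read by MTT assay; on this read-out higher numbers stand for weaker inhibition and lower numbers for stronger inhibition
compound 2 `Cc1nc(Nc2ccccc2)sc1C(=O)/C=C/c1ccc(Cl)cc1`: a limit, > 25000 nM, in this assay

In this assay compound 2 gives no number, only the limit > 25000 nM. Compound 1 stands at a limit as well, > 25000 nM. Among the measured compounds shown here, the one step between measured compounds, a step that the two limits leave unreadable from compound 1 to compound 2, cannot be read in size or direction; both of its ends sit at the limit of > 25000 nM in this assay, at which 2 of the 2 values shown sit.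

Compound 3 `Cc1ccccc1Nc1nc(C)c(C(=O)/C=C/c2ccc(Cl)cc2)s1` differs from compound 2 by methyl in place of hydrogen on an aromatic carbon. For the measured compounds named here, no measured step touches the anilino part of the shared core; the single measured step concerns the aryl group on the chain and is itself unreadable. There is thus no measured basis for expecting compound 3 to move away from where compound 2 stands. The step expected from compound 2 to compound 3 in this assay is a step that the limit leaves unreadable from compound 2 to compound 3, nothing beyond the scatter. Compound 3 is therefore estimated at 30000 nM, within 10000 nM to 100000 nM, with a considerable chance that this assay again returns only a limit.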

Compound 3, half-maximal inhibitory concentration: > 25000 nM
Compound 3: no number, only a limit; the forecaster's own chance of this, stated with the estimate: 75%; the middle value does not contradict the limit.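

In this assay compound 3 gives only a limit, > 25000 nM. Compound 2 also stands at a limit, so no new step can be read between compound 2 and compound 3. All three compounds share one position: the limit of > 25000 nM in this assay, at which 3 of the 3 values shown sit. The compounds shown leave open whether methyl on the anilino ring changes the value in this assay at all, and in which direction.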